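The compounds below may be only part of what the source reports. "The series", "measured", "known", "first", "only" and "open" are said of these compounds alone.

Compound 1 `CCOC(=O)c1cc(=O)c2cc(CSC(=S)N(C(C)C)C(C)C)ccc2o1` is one of two compounds tested in a functional assay on HEp-2 cells (Homo sapiens) for antiproliferative activity, read by MTT assay, with a stated time of 72 h (on this read-out lower numbers stand for stronger inhibition and higher numbers for weaker inhibition), and in that assay compound 1 gives 15900 nM, the highest of the two numbers. The other compound, compound 2 `CN1CCN(C(=S)SCc2coc3ccccc3c2=O)CC1`, gives 2400 nM in this assay; the two structures differ in more than one place, so their values can only be set side by side. Compound 3 `CCOC(=O)c1cc(=O)c2cc(CSC(=S)N3CCOCC3)ccc2o1` is the next compound to be measured. It keeps the core of compound 1 and differs from it at one site: morpholin-4-yl in place of diisopropylamino on a thiocarbonyl carbon. Within the data shown here, no measured step in this assay shows what such a change does. Compound 3 is expected to give a somewhat lower number than compound 1, with a step of a 2.0-fold lower number from compound 1 to compound 3 (0.30 log units; within the scatter) that is estimated to be modest and may not exceed the usual scatter. The estimate for compound 3 in this assay is 8000 nM, within a range of 3000 nM to 25000 nM.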

Compound 3, half-maximal inhibitory concentration: > 25000 nM
Compound 3 ended at the assay's limit; the forecaster's own chance of this, stated with the estimate: 10%; middle value at least 3.1-fold (0.49 log units) from the limit.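

In this assay compound 3 gives > 25000 nM, which is a limit of the assay and not a number. Among these compounds, this provides the first measured step at this position, an at least 1.5-fold higher number from compound 1 to compound 3 (0.19 log units; that floor lies within the scatter), so morpholin-4-yl in place of diisopropylamino on a thiocarbonyl carbon brings no sign of stronger inhibition, although the printed floor alone does not establish a real loss. From the compounds shown here alone, the full size of the step remains unknown because the value of compound 3 is cut off at the limit: the limit of > 25000 nM in this assay, at which 1 of the 3 values shown sits.

The compounds shown leave open how a piperidin-1-yl or dimethylamino group on the same thiocarbonyl carbon would read out in this assay. They also leave open whether a carboxylic acid in place of the ethyl ester would alter the picture for compound 1 or compound 3.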